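Working notes on compound 3 and compound 4

A few compounds are considered here, and "the series" means these few. Any claim that something is new, unique, unknown or untested is made for them only; others in the source may bear on it.

Compound 1 `O=C(Nc1ccc(Oc2ccnc3[nH]ccc23)cc1)c1nn(-c2ccc(Cl)cc2)ccc1=O` and compound 2 `COc1ccc(-n2ccc(=O)c(C(=O)Nc3ccc(Oc4ccnc5[nH]ccc45)c(F)c3)n2)cc1` are the two members with a number in a functional assay on PC-3 cells (Homo sapiens) for cytotoxicity, read by MTT assay, with a stated time of 72 h; on this read-out lower numbers stand for stronger inhibition and higher numbers for weaker inhibition: compound 1 gives 32400 nM, and compound 2 gives 46400 nM. Compound 3 `Cn1ccc2c(Oc3ccc(NC(=O)c4nn(-c5ccc(Cl)cc5)ccc4=O)cc3)ccnc21` reaches only the limit of this assay, > 60000 nM. Among the compounds with values here, the one measured step, an at least 1.8-fold higher number from compound 1 to compound 3 (0.26 log units; that floor lies within the scatter), is methyl in place of hydrogen on an aromatic nitrogen, and it rests on (the limit of > 60000 nM in this assay, at which 1 of the 3 values shown sits). Compound 4 `Cn1ccc2c(Oc3ccc(NC(=O)c4nn(-c5ccc(Br)cc5F)ccc4=O)cc3)ccnc21` keeps that methyl and carries the change (4-bromo-2-fluorophenyl in place of 4-chlorophenyl on an aromatic nitrogen), the 4-bromo-2-fluorophenyl sitting on an aromatic nitrogen of a six-membered aromatic ring with 2 nitrogen. Within the data shown here, no measured step alters this aryl group, so the step from compound 3 to compound 4 has no direct precedent; compound 1 and compound 2 differ in this aryl and in a further place, and both give weak numbers. With compound 3 already at the limit, the expectation is no move beyond the scatter, a step that the limit leaves unreadable from compound 3 to compound 4. Compound 4 is therefore estimated at 80000 nM, within 30000 nM to 250000 nM, most likely again reported only as a limit.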

Compound 4, half-maximal inhibitory concentration: 20500 nM
Compound 4: the middle estimate sits 3.9-fold (0.59 log units) above what was measured, and the stated range ends above it.
By their numbers in this assay, from the lowest: compounds 4, 1 and 2 (each within the scatter of the next, the first and the last beyond it). At a limit, above all of these: compound 3.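

In this assay, the aryl group on the aromatic nitrogen of the six-membered aromatic ring with 2 nitrogen proves to be a place where a change can be read: 4-bromo-2-fluorophenyl in place of 4-chlorophenyl gives an at least 2.9-fold lower number from compound 3 to compound 4 (0.46 log units; beyond the scatter). This size is only a floor, because compound 3 stands at a limit of the assay: the limit of > 60000 nM in this assay, at which 1 of the 4 values shown sits. Compound 4 keeps the methyl on the aromatic nitrogen and still gives a number, so that methyl alone does not hold a compound of this series at the limit.

The compounds shown do not separate the bromine from the fluorine, which enter together in this step. On these data alone, how an amine or a carboxylic acid on this aryl group would read in this assay remains open, as does whether the same aryl change carries over to the core of compound 1, with hydrogen on the aromatic nitrogen.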